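The compounds below may be only part of what the source reports. "The series", "measured", "known", "first", "only" and "open" are said of these compounds alone.

Measured compounds:
- Compound 1, `Oc1ccc(-c2cc(-c3cccc(Cl)c3)nc(-c3ccco3)c2)cc1`: "not determined" (no result reported) in an assay on isolated protein for inhibition of DNA topoisomerase 1 (Homo sapiens), with a stated time of 30 min, tested at 20 uM; a lower number here means a weaker effect, a higher number a stronger effect of the compound at the concentration tested
- Compound 2, `Oc1ccc(-c2cc(-c3cccnc3)nc(-c3cccc(Cl)c3)c2)cc1`: 0%

For the measured compounds named here, the data leave compound 2 as the only compound with a number. Going by the values given here, compound 1 carries no reported result, so nothing can be said about how it compares, and no step between two measured compounds is available. In this assay compound 2 gives 0%, which places it at the bottom of the scale: no inhibition at the concentration tested.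

Compound 3, `Oc1ccc(-c2cc(-c3cccc(Cl)c3)nc(-c3cccs3)c2)cc1`, has not yet been measured. It differs from compound 2 in a single place (thiophen-2-yl in place of pyridin-3-yl on an aromatic carbon). Among the compounds with values here, with only one measured value to go on, no direction of effect can be read from the series itself. The account therefore expects no step beyond the usual scatter of this assay, neither a gain nor a loss, and the expected step of a number 5 percentage points higher from compound 2 to compound 3 (within the scatter) is meant in that sense. For compound 3 the estimate in this assay is 5%, with a range from -5% to 25%, resting on the value of compound 2, 0%.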

Compound 3, a percentage reported as inhibition, at one concentration (the size of the read-out at that concentration, not a potency): 0%
For compound 3 the middle estimate is 5 percentage points above the measured one; measured number inside the range.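

In this assay, for the compounds shown here, thiophen-2-yl in place of pyridin-3-yl on the aromatic carbon next to the ring nitrogen gives no change at the digits printed from compound 2 to compound 3 (within the scatter) and provides the first readable step. Going by these compounds alone, a six-membered aromatic ring with a nitrogen and a five-membered aromatic ring with a sulfur therefore behave alike here: compound 2 at 0% and compound 3 at 0% both sit at the bottom of the scale, so this step cannot show whether the change has any effect on inhibition, only that neither group produces a reading at the concentration tested. No measurement offers an explanation for this result.

The compounds shown leave open whether a group of a different kind at this position, such as an amine, a carboxylic acid or a longer alkyl chain, would give any inhibition at all. They also leave open whether replacing the 3-chlorophenyl or 4-hydroxyphenyl group would lift the read-out from the bottom of the scale, which would make a change at this position measurable.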